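Pyrazole regioisomer swap on a weakly active amide

This account rests on a few compounds, and the source may have more. Where it says the series, first, only, none or still open, it means among the compounds named here.

Measured so far:
- compound 1, `Cc1ccc(OCC(=O)N(Cc2cccs2)c2cnn(C)c2)cc1`: 63000 nM
- compound 2, `CCN(Cc1cccs1)C(=O)/C=C/c1ccc(C)cc1`: 2 nM

Of the compounds shown here, two have been measured in an assay on HEK293 cells for agonist activity at transient receptor potential cation channel subfamily M member 8 (Homo sapiens), read by fluorescence and calcium flux, with a stated time of 15 min; a higher number here means that more compound is needed for the effect, a lower number that less compound is needed. Compound 1 gives 63000 nM, the higher of the two numbers; compound 2 gives 2 nM, a gap that lies far beyond the scatter, and since the two structures differ in several places at once, the gap is not traced to any single change here.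

The next compound, compound 3, `Cc1ccc(OCC(=O)N(Cc2cccs2)c2ccn(C)n2)cc1`, keeps the whole of compound 1 except for the change (1-methyl-1H-pyrazol-3-yl in place of 1-methyl-1H-pyrazol-4-yl on an amide-type nitrogen). The atoms are the same; only the point at which the 1-methyl-1H-pyrazol-3-yl group joins the amide-type nitrogen differs from that of the 1-methyl-1H-pyrazol-4-yl group in compound 1.

Among the measured compounds shown here, no measured pair in this set isolates such a change, so there is no step to lean on. With compound 1 already at 63000 nM, the working expectation is a step of a 1.1-fold lower number from compound 1 to compound 3 (0.02 log units; within the scatter) of no size beyond the scatter, in either direction. Compound 3 is accordingly estimated at 60000 nM, within a range from 15000 nM to 250000 nM, and the measurement will show where it falls.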

Compound 3, half-maximal effective concentration: 855 nM
Compound 3: middle estimate off by 70-fold (1.85 log units), on the high side; measured number below the stated range.
By their numbers in this assay, from the lowest: compound 2; then compound 3; then compound 1.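

In this assay, the point at which the pyrazole joins the amide-type nitrogen matters in its own right: a 74-fold lower number from compound 1 to compound 3 (1.87 log units; beyond the scatter) is a large step beyond the scatter, with no atom added or removed. The two groups match in every count, including heavy atoms, hydrogen-bond donors and acceptors, and charge, so at this position the number follows how the ring is joined, and composition alone does not settle it. Nothing at hand gives a reason for this step, and the data assign it no cause.

The compounds shown leave open whether a 1-methyl-1H-pyrazol-5-yl group, a 1-ethyl-1H-pyrazol-3-yl group, or a phenyl or pyridine ring on the same amide-type nitrogen would extend this step or reverse it. Also open, going by these compounds, is whether the same swap would give a similar step on any core other than that of compound 1: the finding rests on this one pair, and compound 2 differs from both compounds in several places, so it cannot be tied to the change.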